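Acetyl in place of methyl in compound 4

This account rests on a few compounds, and the source may have more. Where it says the series, first, only, none or still open, it means among the compounds named here.

Values in an ADME assay on microsomes from liver (Mus musculus, strain CD-1) for metabolic stability, read by LC-MS, tested at 2 uM (on this read-out higher numbers stand for a longer-lived compound and lower numbers for a shorter-lived compound), for the measured compounds
Compound 1 `Cn1ccc2ccc(-c3cc(Nc4cnccc4C(=O)NCc4cncnc4)cc4nccnc34)cc21` gives 0.4 h
Compound 2 `Cn1cc(NC(=O)c2ccncc2Nc2cc(-c3ccc4ccn(C)c4c3)c3nccnc3c2)cn1` gives 0.2 h
Compound 3 `CN1CCC(NC(=O)c2ccncc2Nc2cc(-c3ccc4ccn(C)c4c3)c3nccnc3c2)CC1` gives > 1 h which is a limit

Compound 3 stands at the limit of > 1 h in this assay, at which 1 of the 3 values shown sits, and this is a limit, not a number. Compound 4 `CC(=O)N1CCC(NC(=O)c2ccncc2Nc2cc(-c3ccc4ccn(C)c4c3)c3nccnc3c2)CC1` differs from compound 3 by acetyl in place of methyl on an amine nitrogen in a ring. Among the compounds with values here, no measured step touches that nitrogen. The nearest evidence comes from changes of the group on the amide-type nitrogen. One such change gave a 2.0-fold lower number from compound 1 to compound 2 (0.30 log units; within the scatter) and so stays small. Two others, both leading to 1-methylpiperidin-4-yl, gave an at least 2.5-fold higher number from compound 1 to compound 3 (0.39 log units; beyond the scatter) and an at least 5.0-fold higher number from compound 2 to compound 3 (0.69 log units; beyond the scatter) as measured. Compound 4 keeps the same ring and alters only the group on its nitrogen, so a change of that larger size is not expected to be undone in full. That expectation rests on compound 3 at > 1 h which is a limit. In this assay the expected step is an at least 1.2-fold lower number from compound 3 to compound 4 (0.09 log units; that floor lies within the scatter) and it is only an estimate. The expected half-life of compound 4 is 0.8 h with an estimated range from 0.3 h to 2 h as its bounds.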

Compound 4, half-life in the Mus musculus assay: 0.117 h
For compound 4 the middle estimate is 6.8-fold (0.83 log units) above the measured one, and the stated range ends above it.
By their numbers in the Mus musculus assay, from the lowest: compounds 4, 2 and 1 (each within the scatter of the next, the first and the last beyond it). At a limit, above all of these: compound 3.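

In the Mus musculus assay compound 3 gives > 1 h, which is a limit. Within the data shown here, in the Mus musculus assay, acetyl in place of methyl on this amine nitrogen in a ring gives an at least 8.5-fold lower number from compound 3 to compound 4 (0.93 log units; beyond the scatter), with compound 4 at 0.117 h, which shows that the group on a nitrogen no earlier step had touched can decide the read-out, while in a physicochemical assay for solubility, read by spectrophotometry, measured as kinetic solubility, at pH 8, tested at 500 uM (on this read-out higher numbers stand for higher solubility and lower numbers for lower solubility), the same change gives a 1.2-fold lower number from compound 3 to compound 4 (0.06 log units; within the scatter), with compound 3 at 246 ug/mL and compound 4 at 213 ug/mL. In the Mus musculus assay, the 1-acetylpiperidin-4-yl group also keeps none of the advantage that 1-methylpiperidin-4-yl had over the earlier groups on the amide-type nitrogen, with a 1.7-fold lower number from compound 2 to compound 4 (0.23 log units; within the scatter) and a 3.4-fold lower number from compound 1 to compound 4 (0.53 log units; beyond the scatter), so the six-membered ring alone does not carry that advantage. The step from compound 3 starts from a limit and not a number, and so gives only a minimum size: the limit of > 1 h in the Mus musculus assay, at which 1 of the 4 values shown sits.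

On these data alone, how far compound 3 truly lies beyond its limit remains open, and with it the full size of the change. Also open, as far as these compounds go, is whether a plain hydrogen or an ethyl group on that ring nitrogen would behave like methyl or like acetyl, which would help to separate the loss of methyl from the arrival of the carbonyl.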